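Dimethylcarbamoyl to acetyl on a shared chromene core

The compounds below may be only part of what the source reports. "The series", "measured", "known", "first", "only" and "open" are said of these compounds alone.

Compound 1, `COc1ccc2c(c1)OC(c1cc(OC)c(OC)c(OC)c1)C(CO)=C2`, in a functional assay for inhibition of nuclear factor NF-kappa-B complex (Homo sapiens) (a higher number here means a weaker inhibitor, a lower number a stronger inhibitor), gives > 50000 nM, a limit of the assay.
Compound 2, `COc1ccc2c(c1)OC(c1cc(OC)c(OC)c(OC)c1)C(C(=O)N(C)C)=C2`, in this assay gives > 50000 nM, also a limit of the assay.

Compound 2 therefore stands at the limit of > 50000 nM in this assay, at which 2 of the 2 values shown sit, so its position is known only as a limit and not as a number. Within the data shown here, the one measured step, a step that the two limits leave unreadable from compound 1 to compound 2, is unreadable for the same reason, and it concerns a different change. Compound 3, `COc1ccc2c(c1)OC(c1cc(OC)c(OC)c(OC)c1)C(C(C)=O)=C2`, differs from compound 2 by methyl in place of dimethylamino on a carbonyl carbon. No measured step bears on this change, so nothing among the shown values argues for a gain or a loss of potency beyond the scatter. Compound 3 is expected to give about 80000 nM, most likely again as a limit, with a range from 20000 nM to 300000 nM. The step that the limit leaves unreadable from compound 2 to compound 3 is thus estimated as none beyond the scatter.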

Compound 3, half-maximal inhibitory concentration: 14100 nM
Estimate against measurement, compound 3: 5.7-fold (0.75 log units) above; measured number outside the range, below it.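

In this assay, the group on this double-bonded ring carbon proves to matter, which the earlier pair could not show because the step between its two limits cannot be read. Methyl in place of dimethylamino on the carbonyl carbon gives an at least 3.5-fold lower number from compound 2 to compound 3 (0.54 log units; beyond the scatter), and acetyl in place of hydroxymethyl gives an at least 3.5-fold lower number from compound 1 to compound 3 (0.54 log units; beyond the scatter); both steps start from a limit, so their full size remains unknown. Compound 3 alone gives a number here, while the other two compounds stay at a limit of the assay: the limit of > 50000 nM in this assay, at which 2 of the 3 values shown sit.

Compound 1 and compound 2 cannot be ranked against each other, so it remains unclear which of their groups lies further from acetyl. Going by these compounds, it also remains open whether a longer ketone such as propanoyl, a carboxylic acid or a primary amide at this carbon would lower the number further or raise it.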